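This account rests on a few compounds, and the source may have more. Where it says the series, first, only, none or still open, it means among the compounds named here.

Compound 1 `COc1ccc(/C=C/c2cc(OC)cc(OC)c2/C=C/C(=O)N2CCCCC2C)cc1` is one of three stilbene-derived amides measured in a functional assay on MCF7 cells (Homo sapiens) for inhibition, read by MTT assay, with a stated time of 48 h (on this read-out lower numbers stand for stronger inhibition and higher numbers for weaker inhibition), where compound 1 gives 4350 nM. This is the highest of the three numbers. Compound 2 `CCCCNC(=O)/C=C/c1c(/C=C/c2ccc(OC)cc2)cc(OC)cc1OC` gives 1330 nM, and compound 3 `COc1ccc(/C=C/c2cc(OC)cc(OC)c2/C=C/C(=O)N2CCC(c3ccccc3)CC2)cc1` gives 4230 nM. The two steps that start from compound 1 both alter the group on the carbonyl carbon: a 3.3-fold lower number from compound 1 to compound 2 (0.51 log units; beyond the scatter), whereas a 1.0-fold lower number from compound 1 to compound 3 (0.01 log units; within the scatter). The pair of compound 2 and compound 3 shows a 3.2-fold higher number from compound 2 to compound 3 (0.50 log units; beyond the scatter).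

Compound 4 `COc1ccc(/C=C/c2cc(OC)cc(OC)c2/C=C/C(=O)N2CCCC(C)C2)cc1` is the next compound, and it differs from compound 1 in the same place: 3-methylpiperidin-1-yl in place of 2-methylpiperidin-1-yl on a carbonyl carbon. The two measured steps on this carbonyl show that a larger change, to 4-phenylpiperidin-1-yl, leaves the number unchanged, while only the change to butylamino moves it. An exchange between two methylpiperidin-1-yl groups is smaller than either, so no step beyond the scatter is expected here, and the estimated step is a 1.1-fold lower number from compound 1 to compound 4 (0.04 log units; within the scatter). Compound 4 is therefore expected to give about 4000 nM in this assay, most likely between 1500 nM and 10000 nM.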

Compound 4, half-maximal inhibitory concentration: 11900 nM
Compound 4: middle estimate off by 3.0-fold (0.47 log units), on the low side; measured number outside the range, above it.
By their numbers in this assay, from the lowest: compound 2; then compounds 3 and 1 (each within the scatter of the next); then compound 4.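

In this assay, shifting the methyl from 2-methylpiperidin-1-yl to 3-methylpiperidin-1-yl (a 2.7-fold higher number from compound 1 to compound 4 (0.44 log units; beyond the scatter)) shows that this group on the carbonyl carbon responds to where a single methyl sits on the piperidine, even with the same atoms, and not only to the change to butylamino. Compound 4 also separates from the 4-phenylpiperidin-1-yl amide (a 2.8-fold higher number from compound 3 to compound 4 (0.45 log units; beyond the scatter)) and from the butylamino amide (an 8.9-fold higher number from compound 2 to compound 4 (0.95 log units; beyond the scatter)), which makes it the weakest of the four. Nothing measured here speaks to the reason for this difference.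

Going by these compounds, whether 4-methylpiperidin-1-yl or plain piperidin-1-yl would fall with compound 1 or with compound 4 remains open. Diethylamino and cyclohexylamino would help separate the role of the amide hydrogen from that of the open chain in compound 2.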